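Moving the Methoxy Group on the Benzyl Arm

A few compounds are considered here, and "the series" means these few. Any claim that something is new, unique, unknown or untested is made for them only; others in the source may bear on it.

Of the compounds shown here, two with the same core have been measured. Compound 1 `O=C(N1CCCC[C@@H]1Cc1ccccc1)n1ncc(C(O)(c2ccc(F)cc2)c2ccc(F)cc2)n1` carries a plain benzyl group on its saturated ring. In an assay on HEK-293T cells for inhibition of diacylglycerol lipase-alpha (Homo sapiens), read by colorimetric assay (on this read-out higher numbers stand for weaker inhibition and lower numbers for stronger inhibition), compound 1 gives 0.794 nM. Compound 2 `COc1ccc(CC2CCCCN2C(=O)n2ncc(C(O)(c3ccc(F)cc3)c3ccc(F)cc3)n2)cc1` differs by a methoxy group on that benzyl ring, and in this assay compound 2 gives 5.01 nM. Compound 2 thus stands at the highest of the two numbers, and its gap to compound 1 lies beyond the usual scatter of repeated measurements.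

Compound 3 `COc1cccc(CC2CCCCN2C(=O)n2ncc(C(O)(c3ccc(F)cc3)c3ccc(F)cc3)n2)c1` is the next step: 3-methoxyphenyl in place of 4-methoxyphenyl on a saturated chain carbon bound to a saturated ring carbon. Among the compounds with values here, no measured pair shows this particular change, so its effect is not known from direct data. Within the data shown here, the one hint is that compound 1, which lacks the methoxy group altogether, gives 0.794 nM in this assay, a stronger result than compound 2. A modest move back toward lower numbers is therefore expected for compound 3, with the step from compound 2 estimated as a 2.0-fold lower number from compound 2 to compound 3 (0.30 log units; within the scatter), possibly no larger than the scatter. Compound 3 is expected to give about 2.5 nM in this assay, with a plausible range from 0.8 nM to 8 nM.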

Compound 3, half-maximal inhibitory concentration: 3.16 nM
Compound 3: middle estimate off by 1.3-fold (0.10 log units), on the low side; measured number inside the range.
By their numbers in this assay, from the lowest: compound 1; then compounds 3 and 2 (each within the scatter of the next).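

Moving the methoxy group, so that 3-methoxyphenyl replaces 4-methoxyphenyl on a saturated chain carbon bound to a saturated ring carbon, gives a 1.6-fold lower number from compound 2 to compound 3 (0.20 log units; within the scatter) in this assay and so leaves no clear difference between the two placements. The two compounds hold the same atoms, so this pair tests only where the methoxy group sits, and in this assay that shift does not separate them. Compound 1, with its plain benzyl group, gives 0.794 nM and remains at a lower number than compound 3, which gives 3.16 nM in this comparison of the benzyl arm. No measurement shown here explains why the two methoxy placements read so much alike.

The compounds shown leave open whether the result is particular to methoxy or would also hold for another group on the benzyl ring, such as a hydroxyl, a chlorine atom or an amine. They also leave open whether a longer chain such as ethoxy, in place of methoxy, would stay as close to these values or move further from the number for the plain benzyl compound.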